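Replacing 3-(methylsulfonyl)phenyl with bromo on compound 3

The source may report more compounds than this note shows. Statements on the series, on what has been measured and on what is new or still open speak of the compounds shown alone.

Compound 1 `CCOC(=O)CCCCCOc1cccc(CN(C(=O)c2ccc(-c3cccc(OC(C)C)c3)cc2)C(C)C)c1` gives > 26000 nM as a limit
Compound 2 `CCOC(=O)CCCCCOc1cccc(CN(C(=O)c2ccc(-c3cc(F)cc(OC)c3)cc2)C(C)C)c1` gives > 26000 nM as a limit
Compound 3 `CCOC(=O)CCCCCOc1cccc(CN(C(=O)c2ccc(-c3cccc(S(C)(=O)=O)c3)cc2)C(C)C)c1` gives > 26000 nM as a limit

All three readings come from an ADME assay on HepG2 cells (Homo sapiens) for cytotoxicity, read by CellTiter-Glo and resazurin assay, with a stated time of 72 h (on this read-out higher numbers stand for an effect only at larger amounts of compound and lower numbers for an effect already at smaller amounts), and none of them is an exact number. Compound 3 shares the limit of > 26000 nM in this assay, at which 3 of the 3 values shown sit, with the other two compounds, so it has no exact place among them.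

Compound 4 `CCOC(=O)CCCCCOc1cccc(CN(C(=O)c2ccc(Br)cc2)C(C)C)c1` differs from compound 3 in one place, with bromo in place of 3-(methylsulfonyl)phenyl on an aromatic carbon. Three measured steps change this same group. They are a step that the two limits leave unreadable from compound 1 to compound 2 and a step that the two limits leave unreadable from compound 1 to compound 3 and a step that the two limits leave unreadable from compound 2 to compound 3 and so none has a readable size. None of them removes the whole ring in favour of bromo, which makes this change a larger one than any measured so far.

Since all three compounds sit at the limit of > 26000 nM in this assay, at which 3 of the 3 values shown sit, no readable step in this assay and no firm direction can be expected. The expected change is a step that the limit leaves unreadable from compound 3 to compound 4 and another limit is the likeliest reading. Compound 4 is estimated at 30000 nM (expected range 15000 nM to 60000 nM).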

Compound 4, half-maximal effective concentration: > 26000 nM
Compound 4 ended at the assay's limit; the forecaster's own chance of this, stated with the estimate: 80%; the middle value is on the limit's open side.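

In this assay compound 4 gives > 26000 nM, which is a limit and not an exact number. No step among compound 1, compound 2, compound 3 and compound 4 can be read, because all four share one reading: the limit of > 26000 nM in this assay, at which 4 of the 4 values shown sit.

These compounds leave open how their true values compare, and whether bromo in place of the ring changes the reading at all.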